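Swapping the amide substituent in a dimethoxy-tetralin acetamide

The source may report more compounds than this note shows. Statements on the series, on what has been measured and on what is new or still open speak of the compounds shown alone.

Two compounds share a saturated bicyclic core carrying two methoxy groups and an acetamide side chain. Compound 1 `CNC(=O)CC1CCc2cc(OC)c(OC)cc21` bears a methylamino amide; in a functional assay on the whole organism (strain Wistar) for inhibition, with Rattus norvegicus as the target, read by paw edema, with stated times of 60 min and 4 h, at a dose of 100 mg/kg by the oral route (a lower number here means less inhibition, a higher number more inhibition at the dose given (going by the name of the read-out)), compound 1 gives 29.7%. Compound 2 `COc1cc2c(cc1OC)C(CC(=O)N(C)C)CC2` carries a dimethylamino amide instead, and in this assay compound 2 gives 35.9%. Among the compounds with values here, the only step measured so far, a number 6.2 percentage points higher from compound 1 to compound 2 (within the scatter), shows that adding one methyl to the amide nitrogen moved the reading within the usual scatter, so compound 2 cannot be separated from compound 1 on these numbers. Compound 3 `COc1cc2c(cc1OC)C(CC(=O)NC(C)C)CC2` takes this further: isopropylamino in place of dimethylamino on a carbonyl carbon. Within the data shown here, since the one related step stayed inside the scatter, the step of a number 3.9 percentage points lower from compound 2 to compound 3 (within the scatter) is expected to stay inside it too. Compound 3 is therefore estimated at 32%, within a range of 18% to 46%.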

Compound 3, a percentage reported as inhibition, in the whole organism at one dose (the size of the read-out at that dose, not a potency): 39.1%
Compound 3: middle estimate off by 7.1 percentage points, on the low side; measured number inside the range.
By their numbers in this assay, from the lowest: compounds 1, 2 and 3 (each within the scatter of the next).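

Across this assay, the step of a number 3.2 percentage points higher from compound 2 to compound 3 (within the scatter) shows that a carbonyl carbon carrying isopropylamino, with 1 hydrogen-bond donor and 4 heavy atoms, cannot be told apart from one carrying dimethylamino, with 0 donors and 3 heavy atoms. The step of a number 9.4 percentage points higher from compound 1 to compound 3 (within the scatter) adds that isopropyl in place of methyl on the amide-type nitrogen also stays inside the scatter, so all three amides remain indistinguishable at this one dose, and this position has so far accepted both a branched group and a fully substituted nitrogen. No measurement is available that would explain these readings.

From the compounds shown here alone, it remains open whether a larger group on the amide nitrogen, such as cyclohexyl or benzyl, would move the reading beyond the scatter. The same question stands for a carboxylic acid in place of the amide, or for a longer chain carrying it.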